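Compound 2 to compound 4: a 2-fluorophenyl swap

The source may report more compounds than this note shows. Statements on the series, on what has been measured and on what is new or still open speak of the compounds shown alone.

Working notes on an ADME assay on Vero 76 cells (Chlorocebus sabaeus) for cytotoxicity, read by neutral red uptake; a higher number here means that more compound is tolerated, a lower number that less compound is tolerated. Of the compounds shown here, three have been measured. Compound 1 (`CC(C)[C@@H](Nc1nc(I)nc2c1ncn2[C@H]1[C@H](O)[C@H](O)[C@]2(CO)C[C@H]12)C1CC1`) gives 46000 nM. Compound 2 (`O[C@@H]1[C@H](O)[C@@H]2C[C@@H]2[C@H]1n1cnc2c(NCC(C3CC3)C3CC3)nc(Cl)nc21`) gives 10000 nM, the lower of the two actual numbers and beyond the scatter from compound 1. Compound 3 (`CC(C)(O)[C@@H](Nc1nc(Cl)nc2c1ncn2[C@H]1[C@H](O)[C@H](O)[C@]2(CO)C[C@H]12)C1CC1`) reads > 100000 nM. That value is a limit of the assay and not a number.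

The next compound is compound 4 (`O[C@@H]1[C@H](O)[C@@H]2C[C@@H]2[C@H]1n1cnc2c(NCc3ccccc3F)nc(Cl)nc21`), which carries 2-fluorophenyl in place of dicyclopropylmethyl on a saturated chain carbon bound to a nitrogen on an aromatic ring. Among the compounds with values here, no measured pair isolates this change, so the direction is a weak expectation. It rests on compound 2 sitting at the low end of the set at 10000 nM, which leaves more room upward than downward. A moderate rise is expected, estimated as a 3.0-fold higher number from compound 2 to compound 4 (0.48 log units; beyond the scatter). For compound 4 the estimated value in this assay is 30000 nM, with an expected range of 8000 nM to 100000 nM.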

Compound 4, half-maximal cytotoxic concentration: 23000 nM
The estimate for compound 4 lay 1.3-fold (0.12 log units) above the measured number, within the range that was stated.
By their numbers in this assay, from the lowest: compound 2; then compounds 4 and 1 (each within the scatter of the next). At a limit, above all of these: compound 3.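

In this assay, within the data shown here, 2-fluorophenyl in place of dicyclopropylmethyl on a saturated chain carbon bound to a nitrogen on an aromatic ring gives a 2.3-fold higher number from compound 2 to compound 4 (0.36 log units; beyond the scatter), the only step in the set that isolates a single change. This position therefore does respond to the group it carries: with the same heavy-atom count in the group that leaves and the group that enters, swapping the two three-membered rings for a fluorinated six-membered aromatic ring lets more compound be tolerated. The step is modest and rests on this one pair, so it shows a direction for this swap and no trend for the position.

On these data alone, whether the fluorine itself matters stays open, as does how an unsubstituted phenyl or a chain carrying an amine would read here. No measured property in these notes bears on the cause of this step.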